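The compounds below may be only part of what the source reports. "The series", "measured", "known", "first", "only" and "open" are said of these compounds alone.

Working notes on the series. Within the data shown here, compound 3 `COc1cc(C(=O)c2ccc3c(ccn3S(=O)(=O)c3cccc(/C=C/C(=O)NO)c3)c2)cc(OC)c1OC` gives 562 nM in an assay on isolated protein for inhibition of protein deacetylase HDAC6 (Homo sapiens) (on this read-out lower numbers stand for stronger inhibition and higher numbers for weaker inhibition), the second highest of the three numbers measured so far. Compound 1 `COc1cc(C(=O)c2ccc3c(ccn3S(=O)(=O)c3ccc(/C=C/C(=O)NO)cc3)c2)cc(OC)c1OC` gives 972 nM in this assay, and the step of a 1.7-fold lower number from compound 1 to compound 3 (0.24 log units; within the scatter) is within the scatter. Compound 2 `O=C(NO)c1ccc(Cn2ccc3cc(C(=O)c4ccc(Cl)cc4)ccc32)cc1` differs from compound 3 in several places at once. In this assay compound 2 gives 6.73 nM.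

Compound 4 `O=C(/C=C/c1cccc(S(=O)(=O)n2ccc3cc(C(=O)c4ccc(F)cc4)ccc32)c1)NO` is to be measured. Its change from compound 3 is 4-fluorophenyl in place of 3,4,5-trimethoxyphenyl on a carbonyl carbon. Among the measured compounds shown here, no measured step bears on this exchange; the only single-point step in the set, from compound 1 to compound 3, concerns a different part of the molecule. The expectation for compound 4 is therefore a step of a 1.4-fold lower number from compound 3 to compound 4 (0.15 log units; within the scatter) in this assay, not beyond the scatter. The estimate for compound 4 is 400 nM, in the range 120 nM to 1500 nM.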

Compound 4, half-maximal inhibitory concentration: 1420 nM
Estimate against measurement, compound 4: 3.6-fold (0.55 log units) below; low and high end bracket the measured number.
By their numbers in this assay, from the lowest: compound 2; then compounds 3, 1 and 4 (each within the scatter of the next, the first and the last beyond it).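

The group on the carbonyl carbon matters in this assay: 4-fluorophenyl in place of 3,4,5-trimethoxyphenyl gives a 2.5-fold higher number from compound 3 to compound 4 (0.40 log units; beyond the scatter). Among these compounds, this is the first single-place step to lie beyond the scatter, and it runs towards weaker inhibition. Nothing available gives a reason for this step.

From the compounds shown here alone, whether the step follows from the methoxy groups leaving or the fluorine entering remains open. Also open, going by these compounds, are how a 4-aminophenyl group on the carbonyl carbon would read and whether the exchange holds with 4-(2-(hydroxycarbamoyl)ethenyl)phenyl on the sulfonyl sulfur.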